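Chloro in Place of Methylcarbamoyl, Starting From a Limit

The compounds below may be only part of what the source reports. "The series", "measured", "known", "first", "only" and "open" are said of these compounds alone.

Compound 1, `COc1ccc(S(=O)(=O)Nc2ccc(NS(=O)(=O)c3ccc(F)cc3)cc2)cc1`, in an assay for inhibition of liver carboxylesterase 1 (Homo sapiens), read by spectrophotometry (a higher number here means a weaker inhibitor, a lower number a stronger inhibitor), is reported only as a limit: > 100000 nM.
Compound 2, `O=C(O)c1ccc(S(=O)(=O)Nc2ccc(NS(=O)(=O)c3ccc(F)cc3)cc2)cc1`, in this assay is likewise a limit: > 100000 nM.
Compound 3, `CNC(=O)c1ccc(S(=O)(=O)Nc2ccc(NS(=O)(=O)c3ccc(F)cc3)cc2)cc1`, in this assay is again a limit: > 100000 nM.

All three measured values sit at the same point, (the limit of > 100000 nM in this assay, at which 3 of the 3 values shown sit), so none of them is a number that can be compared. The steps between them, a step that the two limits leave unreadable from compound 1 to compound 2, a step that the two limits leave unreadable from compound 1 to compound 3 and a step that the two limits leave unreadable from compound 2 to compound 3, are therefore unreadable in size and direction. Compound 3 stands at that limit with nothing to set it apart from compounds 1 and 2.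

Compound 4, `O=S(=O)(Nc1ccc(NS(=O)(=O)c2ccc(Cl)cc2)cc1)c1ccc(F)cc1`, differs from compound 3 by chloro in place of methylcarbamoyl on an aromatic carbon. Among the measured compounds shown here, no measured step covers this kind of change, and the measured steps give no readable size at all, so no direction can be drawn from them. The expected step of a number no higher from compound 3 to compound 4 (the limit leaves the size open) is accordingly set near zero, and compound 4 is estimated at 100000 nM, within 30000 nM to 300000 nM, with a fair chance that only a limit is reported.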

Compound 4, inhibition constant: > 100000 nM
Compound 4 ended at the assay's limit; the forecaster's own chance of this, stated with the estimate: 65%; the middle value sits exactly at the limit.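

Compound 4, like compounds 1, 2 and 3, is reported only as a limit, so its steps to those three cannot be read in size or direction: the limit of > 100000 nM in this assay, at which 4 of the 4 values shown sit.

From the compounds shown here alone, what stays open is whether any of these four compounds truly differs from the others in this assay.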